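A few compounds are considered here, and "the series" means these few. Any claim that something is new, unique, unknown or untested is made for them only; others in the source may bear on it.

Compound 1 `O=C(Nc1ccc2c(c1)N(Cc1ccc(C(=O)NO)cc1)CC2)Nc1ccc(Cl)c(C(F)(F)F)c1` gives 3100 nM in a functional assay on PC-3 cells (Homo sapiens) for inhibition, read by sulforhodamine B assay, with a stated time of 48 h; a lower number here means a stronger inhibitor, a higher number a weaker inhibitor. Compound 2 `O=C(Nc1ccc2c(c1)CCCN2c1ccc(C(=O)NO)cc1)Nc1ccc(Cl)c(C(F)(F)F)c1` gives 3000 nM in this assay. Compound 3 `O=C(CCCCCCC(=O)Nc1ccc(NC(=O)Nc2ccc(Cl)c(C(F)(F)F)c2)cc1)NO` gives 4600 nM in this assay.

Compound 3 gives the highest of the three numbers, yet its gaps to compound 1 and to compound 2 both lie within the scatter, so the three compounds stand together with no order among them. Compound 4 `O=C(CCCC(=O)Nc1ccc(NC(=O)Nc2ccc(Cl)c(C(F)(F)F)c2)cc1)NO` is not yet measured. It differs from compound 3 in one place: hydroxycarbamoyl in place of 3-(hydroxycarbamoyl)propyl on a saturated chain carbon, three bonds along the chain from a carbonyl carbon. Among the compounds with values here, no step between measured compounds speaks to a change of this kind, so the expectation rests on compound 3 alone. A weakening step is expected, with the estimated change given by a 2.6-fold higher number from compound 3 to compound 4 (0.42 log units; beyond the scatter). Compound 4 is expected to give about 12000 nM in this assay, within a range of 4000 nM to 40000 nM.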

Compound 4, half-maximal inhibitory concentration: > 10000 nM
Compound 4: only a limit was reported; the forecaster's own chance of this, stated with the estimate: 15%; the middle value does not contradict the limit.
By their numbers in this assay, from the lowest: compounds 2, 1 and 3 (each within the scatter of the next). At a limit, above all of these: compound 4.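

In this assay, hydroxycarbamoyl in place of 3-(hydroxycarbamoyl)propyl on this saturated chain carbon gives an at least 2.1-fold higher number from compound 3 to compound 4 (0.33 log units; beyond the scatter) as a weakening step. Within the data shown here, the earlier compounds stood together within the scatter and offered no step at this position, so this is the first sign that the change matters here. For compound 4 the reading is a limit, not a number: the limit of > 10000 nM in this assay, at which 1 of the 4 values shown sits.

On these data alone, how far the weakening goes therefore stays open. So does the effect of a longer chain, or of a carboxylic acid in place of the hydroxycarbamoyl group, at this position.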